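A halogen swap from compound 2 to compound 3

The source may report more compounds than this note shows. Statements on the series, on what has been measured and on what is new or still open speak of the compounds shown alone.

In an ADME assay on L929 cells (Mus musculus) for cytotoxicity, read by MTT assay, with a stated time of 72 h (on this read-out higher numbers stand for weaker inhibition and lower numbers for stronger inhibition), compound 1 (`Cc1ccc(S(=O)(=O)n2cc(COC3=C/C(=N\c4ccc(I)cc4)c4ccccc4C3=O)nn2)cc1`) gives > 20000 nM as a limit of the assay, not a number. Compound 2 (`Cc1ccc(S(=O)(=O)n2cc(COC3=C/C(=N\c4ccc(Br)cc4)c4ccccc4C3=O)nn2)cc1`) gives > 20000 nM as a limit too, so its standing is known only as that limit. Compound 3 (`Cc1ccc(S(=O)(=O)n2cc(COC3=C/C(=N\c4ccc(Cl)cc4)c4ccccc4C3=O)nn2)cc1`), not yet measured, has chloro in place of bromo on an aromatic carbon, para to a large group (chloro in place of bromo on an aromatic carbon) and otherwise matches compound 2. Among the measured compounds shown here, the only measured step bearing on this change is the swap of iodo for bromo, a step that the two limits leave unreadable from compound 1 to compound 2 and it offers no size to carry over. No step beyond the scatter is expected in this assay in either direction, since the record holds only the limit of > 20000 nM in this assay, at which 2 of the 2 values shown sit, and nothing more. The expected step is a step that the limit leaves unreadable from compound 2 to compound 3 on this estimate. Compound 3 is estimated at 22000 nM with an expected range from 11000 nM to 40000 nM for the measurement.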

Compound 3, half-maximal inhibitory concentration: > 20000 nM
Compound 3 was reported as a limit (the forecaster's own chance of this, stated with the estimate: 75%); the middle value lies beyond the limit too.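

Compound 3, like compound 1 and compound 2, is reported in this assay only as a limit, so no step among the three can be read: the limit of > 20000 nM in this assay, at which 3 of the 3 values shown sit.

The compounds shown leave open whether iodo, bromo or chloro makes any difference in this assay, and what actual value each compound would give.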